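The compounds below may be only part of what the source reports. "The series", "measured", "known", "first", "only" and "open" are said of these compounds alone.

In a functional assay on SiHa cells (Homo sapiens) for cytotoxicity, read by MTT assay, with a stated time of 48 h (a lower number here means a stronger inhibitor, a higher number a weaker inhibitor), compound 3 `CCCCCCCCCCCCCCNC(=O)[C@@H](NC(=O)c1cc2ccccc2[nH]1)[C@@H](C)O` gives 14200 nM. Compound 1 `CCCCCCCCCCCCCCNC(=O)[C@@H](N)[C@@H](C)O` gives 11000 nM, and the step of a 1.3-fold higher number from compound 1 to compound 3 (0.11 log units; within the scatter) lies within the scatter, so the two cannot be ranked against each other. Compound 2 `C/C=C/C=C/C(=O)N[C@H](C(=O)NCCCCCCCCCCCC)[C@@H](C)O` returns only a limit of the assay, > 200000 nM. Compound 4 `C/C=C/C=C/C(=O)N[C@H](C(=O)NCCCCCCCCCCCCCC)[C@@H](C)O` carries the change (penta-1,3-dien-1-yl in place of 1H-indol-2-yl on a carbonyl carbon). Within the data shown here, no measured step covers this change directly; what bears on it is that compound 2 carries the same (penta-1,3-dien-1-yl)carbonyl on the amine nitrogen and sits at the limit of > 200000 nM in this assay, at which 1 of the 3 values shown sits. A step toward a weaker inhibitor, beyond the scatter, is therefore expected, an 11-fold higher number from compound 3 to compound 4 (1.02 log units; beyond the scatter). For compound 4 this assay is expected to give 150000 nM, within 40000 nM to 400000 nM, with a fair chance that only a limit is reported.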

Compound 4, half-maximal inhibitory concentration: > 200000 nM
Compound 4 ended at the assay's limit; the forecaster's own chance of this, stated with the estimate: 50%; middle value at least 1.3-fold (0.12 log units) away from the limit.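

In this assay compound 4 reads > 200000 nM, which is a limit of the assay and not a number. Replacing the group on the carbonyl carbon gives an at least 14-fold higher number from compound 3 to compound 4 (1.14 log units; beyond the scatter), and acylating the free amine nitrogen with (penta-1,3-dien-1-yl)carbonyl gives an at least 18-fold higher number from compound 1 to compound 4 (1.25 log units; beyond the scatter). The (1H-indol-2-yl)carbonyl group therefore stays within the scatter of the free amine, while the (penta-1,3-dien-1-yl)carbonyl group does not.

As far as these compounds go, the step between the two limits, compound 2 to compound 4, cannot be read, so the effect of chain length remains open. From the compounds shown here alone, whether a saturated hexanoyl group or a benzoyl group on that nitrogen behaves like either group is also open.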